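Anilino in place of benzyl(methyl)amino on compound 1

The compounds below may be only part of what the source reports. "The series", "measured", "known", "first", "only" and "open" are said of these compounds alone.

Measured compounds:
compound 1 `CN(Cc1ccccc1)C(=O)c1nc(Cc2ccccc2C(F)(F)F)n(C)c(=O)c1O`: > 100000 nM
compound 2 `Cn1c(Cc2ccccc2)nc(C(=O)NCc2ccccc2)c(O)c1=O`: > 100000 nM
compound 3 `CCn1c(Cc2ccccc2C(F)(F)F)nc(C(=O)NCc2ccccc2)c(O)c1=O`: > 100000 nM

In an ADME assay on HepG2 cells (Homo sapiens) for cytotoxicity, in the presence of a further agent that is not named here (on this read-out lower numbers stand for stronger inhibition and higher numbers for weaker inhibition), compound 1 gives > 100000 nM, which is a limit and not a number. The series as a whole stands at the limit of > 100000 nM in this assay, at which 3 of the 3 values shown sit. Compound 4 `Cn1c(Cc2ccccc2C(F)(F)F)nc(C(=O)Nc2ccccc2)c(O)c1=O` carries anilino in place of benzyl(methyl)amino on a carbonyl carbon. Within the data shown here, no measured pair differs in one place only, so no measured step is available. The expectation therefore rests on compound 1 at > 100000 nM, a limit. No change beyond the scatter is expected in this assay, and the expected step is a number no higher from compound 1 to compound 4 (the limit leaves the size open). For compound 4 the estimated value is 100000 nM, with an expected range of 50000 nM to 200000 nM.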

Compound 4, half-maximal inhibitory concentration: > 100000 nM
Compound 4: no number, only a limit; the forecaster's own chance of this, stated with the estimate: 85%; the middle value sits exactly at the limit.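

No step can be read from compound 1 to compound 4 in this assay, because both results are limits and not numbers: the limit of > 100000 nM in this assay, at which 4 of the 4 values shown sit. The compounds shown leave open how anilino and benzyl(methyl)amino compare on this read-out.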